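The source may report more compounds than this note shows. Statements on the series, on what has been measured and on what is new or still open speak of the compounds shown alone.

Measured compounds on the shared core:

compound 1 `N[C@H]1CC[C@H](Nc2c(C(=O)NCc3ccc(Cl)cc3)nc(Br)c3cccnc23)CC1` — 2000 nM
compound 3 `N[C@H]1CC[C@H](Nc2c(C(=O)NCc3ccc(F)cc3)nc(Br)c3cccnc23)CC1` — 2000 nM
compound 2 `N[C@H]1CC[C@H](Nc2c(C(=O)NCc3ccccn3)nc(Br)c3cccnc23)CC1` — "not determined" (no result reported)

In a functional assay on SK-BR-3 cells (Homo sapiens) for cytotoxicity, read by MTT assay, with a stated time of 72 h (on this read-out lower numbers stand for stronger inhibition and higher numbers for weaker inhibition), compound 3 gives 2000 nM, and in this assay compound 1 gives 2000 nM. For the measured compounds named here, the only step that can be followed across the measured set, no change at the digits printed from compound 1 to compound 3 (within the scatter), shows no change at the digits printed; compound 3 thus stands level with compound 1, and compound 2 adds nothing to the comparison, having no number.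

Compound 4 `N[C@H]1CC[C@H](Nc2c(C(=O)NCc3ccccc3)nc(Br)c3cccnc23)CC1` is the next entry. Its difference from compound 3 is hydrogen in place of fluoro on an aromatic carbon. Going by the values given here, the one relevant precedent is the swap of one halogen for another at the same aromatic carbon, where no change at the digits printed from compound 1 to compound 3 (within the scatter) stayed within the scatter. Nothing in the measured compounds shows that the substituent at this position moves the read-out in either direction, so the step from compound 3 to compound 4 is expected to be within the scatter as well, no change at the digits printed from compound 3 to compound 4 (within the scatter), in this assay.

Compound 4 is therefore estimated at 2000 nM in this assay, with a range from 1000 nM to 4000 nM.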

Compound 4, half-maximal inhibitory concentration: 8000 nM
Compound 4: middle estimate off by 4.0-fold (0.60 log units), on the low side; the measured number lies above the stated range.
By their numbers in this assay, from the lowest: compounds 1 and 3 (each within the scatter of the next); then compound 4.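

In this assay this aromatic carbon is not indifferent to what it carries: hydrogen in place of fluoro gives a 4.0-fold higher number from compound 3 to compound 4 (0.60 log units; beyond the scatter) and hydrogen in place of chloro gives a 4.0-fold higher number from compound 1 to compound 4 (0.60 log units; beyond the scatter) in the same direction. The earlier swap of one halogen for the other gave no change at the digits printed from compound 1 to compound 3 (within the scatter) and so showed only that fluoro and chloro read alike here, whereas the two new steps show that either halogen goes with a lower number than hydrogen, and none of these three compounds goes against that. No measurement at hand accounts for this difference.

As far as these compounds go, whether the lower number belongs to halogens in particular or to any group at this carbon stays open, and a methyl, a methoxy, a nitrile or an amine in the same place would help to separate the two readings. Also open, from the compounds shown here alone, is whether the same step holds with the halogen on another carbon of this ring, or with a longer chain in place of the benzyl methylene.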